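Working notes on a hepatoma cell growth inhibition series

The source may report more compounds than this note shows. Statements on the series, on what has been measured and on what is new or still open speak of the compounds shown alone.

Measured so far:
compound 1 `C/C(=N\NC(=O)c1ccc(CSc2nc3ccccc3s2)cc1)c1ccc(C)c([N+](=O)[O-])c1` — in a functional assay on Huh-7 cells (Homo sapiens) for inhibition, read by MTT assay, with a stated time of 72 h (a lower number here means a stronger inhibitor, a higher number a weaker inhibitor), compound 1 gives > 80 ug/mL
compound 2 `O=C(N/N=C/c1c[nH]c2ccccc12)c1ccc(CSc2nc3ccccc3s2)cc1` — in this assay compound 2 gives 7.74 ug/mL

The value for compound 1 in this assay is a limit of the assay, not a number: compound 1 sits at the limit of > 80 ug/mL in this assay, at which 1 of the 2 values shown sits. Among the measured compounds shown here, compound 2 is the one member of the pair with a number; no step between compound 1 and compound 2 is computed here, so only the two values as they stand are recorded.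

Compound 3 `C/C(=N\NC(=O)c1ccc(CSc2nc3ccccc3s2)cc1)c1ccc([N+](=O)[O-])cc1` is not yet measured in this assay. It differs from compound 1 by 4-nitrophenyl in place of 4-methyl-3-nitrophenyl on a carbon with a double bond to nitrogen, a change within a single aromatic substituent while the shared core of compound 1 stays untouched. For the measured compounds named here, with no measured step for this kind of change, a small step is expected, in neither direction beyond the scatter, and a further limit read-out is thought likely. Compound 3 is therefore estimated at 70 ug/mL, within 25 ug/mL to 200 ug/mL, the step of an at least 1.1-fold lower number from compound 1 to compound 3 (0.05 log units; that floor lies within the scatter) being the expected outcome.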

Compound 3, half-maximal inhibitory concentration: 4.46 ug/mL
Compound 3: middle estimate off by 16-fold (1.20 log units), on the high side; measured number outside the range, below it.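

In this assay compound 3 gives 4.46 ug/mL, and 4-nitrophenyl in place of 4-methyl-3-nitrophenyl on a carbon with a double bond to nitrogen produces an at least 17-fold lower number from compound 1 to compound 3 (1.25 log units; beyond the scatter). Among the compounds shown here, this is the first readable step, and it shows that activity here is sensitive to a change within this single aromatic substituent while the shared core stays untouched. Compound 1 carries a limit of the assay and not a number, so the size of the step is a floor only: the limit of > 80 ug/mL in this assay, at which 1 of the 3 values shown sits.

The change removes the methyl group and also alters the place of the nitro group, and the compounds shown do not tell which of the two carries the step. From the compounds shown here alone, how an amine or a carboxylic acid in place of the nitro group would read in this assay also stays open.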